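Trichloromethyl Sulfone Analogue Expected to Remain Inactive

The compounds below may be only part of what the source reports. "The series", "measured", "known", "first", "only" and "open" are said of these compounds alone.

Compound 1 `O=[N+]([O-])c1cc(S(=O)(=O)C(F)(F)F)ccc1NC1CCCCC1` — > 1000000 nM
Compound 2 `O=[N+]([O-])c1cc(S(=O)(=O)C(Cl)Cl)ccc1NC1CCCCC1` — > 1000000 nM

In an assay on cells for inhibition of serine/threonine-protein kinase WNK1 (Homo sapiens), read by luminescence and Kinase-Glo, with a stated time of 2 h (a lower number here means a stronger inhibitor, a higher number a weaker inhibitor), compound 1 gives only a limit, > 1000000 nM. Compound 2 likewise gives only a limit, > 1000000 nM. The step that the two limits leave unreadable from compound 1 to compound 2 is therefore unreadable in size and direction, and both results sit at the limit of > 1000000 nM in this assay, at which 2 of the 2 values shown sit. Compound 3 `O=[N+]([O-])c1cc(S(=O)(=O)C(Cl)(Cl)Cl)ccc1NC1CCCCC1` differs from compound 2 by chloro in place of hydrogen on a saturated chain carbon bound to two chlorine atoms and a sulfonyl sulfur. No readable step bears on this change, so nothing beyond the scatter can be expected in either direction. Compound 3 is estimated at 1000000 nM, between 200000 nM and 5000000 nM, an estimated step of a number no higher from compound 2 to compound 3 (the limit leaves the size open).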

Compound 3, half-maximal inhibitory concentration: > 1000000 nM
Compound 3: a limit, no number; the forecaster's own chance of this, stated with the estimate: 85%; the middle value lies on the limit itself.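

In this assay, going by these compounds alone, compound 3 also gives only a limit, so no step among compound 1, compound 2 and compound 3 can be read: (the limit of > 1000000 nM in this assay, at which 3 of the 3 values shown sit). The compounds shown leave open how these three rank against one another, and whether any group on the sulfonyl sulfur gives measurable inhibition.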